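Methyl for Chloro on the Anilide Ring of Thiosemicarbazones

This account rests on a few compounds, and the source may have more. Where it says the series, first, only, none or still open, it means among the compounds named here.

Compound 1 `Oc1ccc(/C=N/NC(=S)Nc2ccc(Cl)cc2)cc1` was tested in an assay for inhibition of ribonucleoside-diphosphate reductase RR1 (Homo sapiens), with a stated time of 30 min (on this read-out higher numbers stand for weaker inhibition and lower numbers for stronger inhibition), where compound 1 gives 287000 nM. Compound 2 `Oc1ccc(/C=N/NC(=S)Nc2cccc(Cl)c2)cc1` shares the same atoms joined differently; the difference between the two cores is not broken down here. In this assay compound 2 gives 29300 nM. Compound 3 `Cc1cccc(NC(=S)N/N=C/c2ccc(O)cc2)c1` is derived from compound 2 by the change (methyl in place of chloro on an aromatic carbon), and compound 3 gives 30400 nM; the step was a 1.0-fold higher number from compound 2 to compound 3 (0.02 log units; within the scatter). Compound 4 `Cc1ccc(NC(=S)N/N=C/c2ccc(O)cc2)cc1` arises from compound 1 by the same kind of change, (methyl in place of chloro on an aromatic carbon), though here the place is para to a large group rather than meta to a large group. Because the step of a 1.0-fold higher number from compound 2 to compound 3 (0.02 log units; within the scatter) was flat, compound 4 is expected to sit close to compound 1, a step of a 1.1-fold lower number from compound 1 to compound 4 (0.04 log units; within the scatter), with this assay estimated to give compound 4 about 260000 nM within 90000 nM to 750000 nM.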

Compound 4, half-maximal inhibitory concentration: 14200 nM
For compound 4 the middle estimate is 18-fold (1.26 log units) above the measured one; the measured number lies below the stated range.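

In this assay, methyl in place of chloro on an aromatic carbon, para to a large group, gave a 20-fold lower number from compound 1 to compound 4 (1.31 log units; beyond the scatter). Set beside the flat step on the other core, the same change did not carry over with the same size: the same change on two cores in this assay, a 1.0-fold higher number (0.02 log units; within the scatter) from compound 2 to compound 3 and a 20-fold lower number (1.31 log units; beyond the scatter) from compound 1 to compound 4, 21-fold (1.32 log units) apart, beyond the scatter of two such steps. This shows that the result of this change on one core cannot be assumed for another in this series, but it does not show why the two steps differ, and two pairs set no general rule.

The compounds shown leave open how other groups in the same place, such as methoxy, an amine or a carboxylic acid, would read in this assay. They also leave open whether fluoro or bromo would track chloro or methyl.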